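This account rests on a few compounds, and the source may have more. Where it says the series, first, only, none or still open, it means among the compounds named here.

For the measured compounds named here, compound 3 `N#CC1=C(N)N(c2ccc(S(N)(=O)=O)cc2)C2=C(C(=O)CCC2)C1c1ccc([N+](=O)[O-])cc1` gives the only number in a functional assay on Ehrlich cells (Mus musculus) for antiproliferative activity, read by trypan blue exclusion, with a stated time of 2 h (a lower number here means a stronger inhibitor, a higher number a weaker inhibitor), namely 2.5 ug/mL. Compound 1 `N#CC1=C(N)N(c2ccc(S(N)(=O)=O)cc2)C2=C(C(=O)CCC2)C1c1ccccc1` sits at a limit of this assay, > 100 ug/mL. Compound 2 `COc1ccccc1C1C(C#N)=C(N)N(c2ccc(S(N)(=O)=O)cc2)C2=C1C(=O)CCC2` likewise sits at a limit of this assay, > 100 ug/mL. Compound 4 `Cc1ccoc1C1C(C#N)=C(N)N(c2ccc(S(N)(=O)=O)cc2)C2=C1C(=O)CCC2` carries 3-methylfuran-2-yl in place of 4-nitrophenyl on a saturated ring carbon. Going by the values given here, two measured steps bear on this change: an at least 40-fold lower number from compound 2 to compound 3 (1.60 log units; beyond the scatter) and an at least 40-fold lower number from compound 1 to compound 3 (1.60 log units; beyond the scatter), both arriving at compound 3 from the limit of > 100 ug/mL in this assay, at which 2 of the 3 values shown sit. Both brought the 4-nitrophenyl onto the saturated ring carbon; compound 4 takes it away again for a 3-methylfuran-2-yl, so a large step back toward that limit is expected, a 24-fold higher number from compound 3 to compound 4 (1.38 log units; beyond the scatter). Compound 4 is accordingly estimated at 60 ug/mL, with a range from 10 ug/mL to 200 ug/mL.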

Compound 4, half-maximal inhibitory concentration: > 100 ug/mL
Compound 4: no number, only a limit (the forecaster's own chance of this, stated with the estimate: 50%); middle value at least 1.6-fold (0.22 log units) from the limit.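

Putting 3-methylfuran-2-yl in place of 4-nitrophenyl on the saturated ring carbon gives an at least 40-fold higher number from compound 3 to compound 4 (1.60 log units; beyond the scatter), so a five-membered aromatic ring with a hetero atom does not retain the activity of compound 3. Compound 4 gives only a limit, > 100 ug/mL, and its steps to compound 1 and compound 2 cannot be read. In this assay, 4-nitrophenyl remains the only group at this position with a number, and the other three compounds share one limit: the limit of > 100 ug/mL in this assay, at which 3 of the 4 values shown sit.

On these data alone, whether activity depends on the nitro group specifically remains open. An amine or a carboxylic acid in its place on the phenyl ring would test this.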